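Notes on a sulfamoyl-to-sulfonamide switch in the series

The source may hold more compounds than are shown below. What is called first, only, known or untested is meant among the compounds shown, and "the series" means these compounds.

Measured compounds:
compound 1 `CN(C[C@@H]1CCCc2cc(S(=O)(=O)c3cccc(F)c3)ccc21)S(N)(=O)=O` — 3.98 nM
compound 2 `O=S(=O)(O)CCCNC[C@@H]1CCCc2cc(S(=O)(=O)c3cccc(F)c3)ccc21` — 1.26 nM
compound 3 `CN(C[C@@H]1CCCc2cc(S(=O)(=O)c3cccc(F)c3)ccc21)C(N)=O` — 39.8 nM

All three were run in an assay on isolated protein for displacement of a labelled ligand from 5-hydroxytryptamine receptor 6 (Homo sapiens); on this read-out lower numbers stand for stronger inhibition and higher numbers for weaker inhibition. Compound 3 holds the highest number of the three: the two gaps that lead up to it are a 10-fold higher number from compound 1 to compound 3 (1.00 log units; beyond the scatter) and a 32-fold higher number from compound 2 to compound 3 (1.50 log units; beyond the scatter). Compound 1 and compound 2 are separated by a 3.2-fold lower number from compound 1 to compound 2 (0.50 log units; beyond the scatter).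

The next compound is compound 4 `CS(=O)(=O)NC[C@@H]1CCCc2cc(S(=O)(=O)c3cccc(F)c3)ccc21`. Relative to compound 3 the change is methanesulfonamido in place of carbamoyl(methyl)amino on a saturated chain carbon bound to a saturated ring carbon.

Two of the measured steps bear on this. Replacing sulfamoyl with carbamoyl on the amine nitrogen gives a 10-fold higher number from compound 1 to compound 3 (1.00 log units; beyond the scatter); read the other way, toward sulfamoyl, that is a modest drop in the number. Compound 4 keeps a sulfonyl group at that position, with the methyl now on sulfur rather than on nitrogen, so the same kind of move is expected. The step from compound 2 to compound 3 shows that the sulfur-bearing groups in this set have, so far, given the lower numbers.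

For compound 4 in this assay a number close to that of compound 1 is therefore expected, a step of a 6.6-fold lower number from compound 3 to compound 4 (0.82 log units; beyond the scatter). The estimate for compound 4 is 6 nM, with a range from 2 nM to 20 nM.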

Compound 4, inhibition constant: 0.2 nM
Compound 4: middle estimate off by 30-fold (1.48 log units), on the high side, and the stated range ends above it.
By their numbers in this assay, from the lowest: compound 4; then compound 2; then compound 1; then compound 3.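

In this assay, methanesulfonamido on a saturated chain carbon bound to a saturated ring carbon gives a 200-fold lower number from compound 3 to compound 4 (2.30 log units; beyond the scatter) and also outdoes both earlier sulfur-bearing groups, with a 20-fold lower number from compound 1 to compound 4 (1.30 log units; beyond the scatter) and a 6.3-fold lower number from compound 2 to compound 4 (0.80 log units; beyond the scatter). Compound 4 therefore holds the lowest number of the four, and the steps from compound 1 and compound 2 show that a sulfur-bearing group at this position does not by itself fix the level, since compound 1 also carries a sulfonyl group on the amine nitrogen yet stands well above compound 4. No measurement in hand accounts for the size of these steps.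

The step from compound 3 also swaps carbonyl for sulfonyl and removes the methyl from the amine nitrogen in one move, so the share of each remains unresolved, and acetamido and the nitrogen-methylated form of methanesulfonamido would be the groups that separate them. Also open, on these data alone, is whether a longer chain on the sulfur, as in ethanesulfonamido, or a ring such as benzenesulfonamido, holds the number of compound 4 at 0.2 nM.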